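Shortening the Chain on the Nitrogen of a Weak Inhibitor

The source may report more compounds than this note shows. Statements on the series, on what has been measured and on what is new or still open speak of the compounds shown alone.

Of the compounds shown here, three built on a shared core have been tested in a functional assay on MCF7 cells (Homo sapiens) for antiproliferative activity; a higher number here means a weaker inhibitor, a lower number a stronger inhibitor. Compound 1 `COc1cc(Cc2nc3c(N)ncnc3n2CC2CCCCC2)cc(OC)c1OC` gives 39800 nM in this assay, the highest of the three numbers. Compound 2 `C#CCCn1c(Cc2cc(OC)c(OC)c(OC)c2)nc2c(N)nc(F)nc21` gives 25100 nM in this assay, and compound 3 `CCCCn1c(Cc2cc(OC)c(OC)c(OC)c2Br)nc2c(N)ncnc21` gives 25100 nM in this assay. Both of these numbers sit within the usual scatter of the number for compound 1, so the three compounds cannot be told apart on potency; all three are weak inhibitors of cell growth.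

Compound 4 `COc1cc(Cc2nc3c(N)ncnc3n2C)cc(OC)c1OC` has not yet been measured in this assay. It differs from compound 1 in one place: hydrogen in place of cyclohexyl on a saturated chain carbon bound to an aromatic nitrogen. Nothing measured here shows what happens when that saturated chain on the aromatic nitrogen is cut down. The three measured compounds carry different groups on that nitrogen and all land in the same weak range. Compound 4 is therefore expected to stay weak, with the step of a 1.8-fold higher number from compound 1 to compound 4 (0.25 log units; within the scatter) estimated to be small, at most around the edge of the scatter, toward a slightly weaker inhibitor. The estimate for compound 4 is 70000 nM, with a range from 20000 nM to 250000 nM.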

Compound 4, half-maximal inhibitory concentration: 70800 nM
Compound 4: the middle estimate sits 1.0-fold (0.00 log units) below what was measured; the measured number falls inside the stated range.
By their numbers in this assay, from the lowest: compounds 2, 3, 1 and 4 (each within the scatter of the next, the first and the last beyond it).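

This is the only pair shown that differs in a single place, so it gives a direct reading of this position. In this assay, hydrogen in place of cyclohexyl on a saturated chain carbon bound to an aromatic nitrogen gives a 1.8-fold higher number from compound 1 to compound 4 (0.25 log units; within the scatter), which means that cutting cyclohexylmethyl down to methyl removes the whole ring without a change that can be told from scatter, and both compounds remain weak inhibitors. No measurement shown accounts for this result.

On these data alone, it remains open whether any other group at this place could give a step beyond the scatter, since this pair covers only cyclohexyl and hydrogen. A primary amine or a carboxylic acid at the end of a longer chain would test this position in a way that these two compounds cannot.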